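The source may hold more compounds than are shown below. What is called first, only, known or untested is meant among the compounds shown, and "the series" means these compounds.

Compound 1, `O=C(NO)c1ccc(CNCc2nnnn2Cc2ccccc2)cc1`, gives 100 nM in an assay on isolated protein for inhibition of protein deacetylase HDAC6 (Homo sapiens), read by fluorescence, with a stated time of 90 min; on this read-out higher numbers stand for weaker inhibition and lower numbers for stronger inhibition.
Compound 2, `O=C(NO)c1ccc(CNC(c2ccccc2)c2nnnn2C2CCCCC2)cc1`, gives 120 nM in this assay.
Compound 3, `O=C(NO)c1ccc(CNC(c2ccccc2)c2nnnn2Cc2ccccc2)cc1`, gives 100 nM in this assay.

All three share the same core and differ only in the groups attached to it. In this assay compound 3 stands level with compound 1 at the digits shown, and these two together carry the lowest numbers of the three; compound 2 lies closest to them, its number being only slightly higher, and that difference is within the scatter.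

Compound 4, `CCCCC(NCc1ccc(C(=O)NO)cc1)c1nnnn1Cc1ccccc1`, has not yet been measured. It differs from compound 3 in one place: butyl in place of phenyl on a saturated chain carbon bound to an amine nitrogen and an aromatic carbon.

Within the data shown here, one measured step bears directly on this position. Going from compound 1 to compound 3, a phenyl was put in place of a hydrogen on the same saturated chain carbon, and the result was no change at the digits printed from compound 1 to compound 3 (within the scatter). The step of a 1.2-fold lower number from compound 2 to compound 3 (0.08 log units; within the scatter) concerns a different place and says nothing about this carbon. Since a hydrogen and a phenyl at this position gave the same number, a butyl there is expected to behave alike, with no step beyond the scatter in this assay.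

Compound 4 is therefore estimated to give 110 nM in this assay, within a range of 50 nM to 250 nM. The expected step from compound 3 to compound 4 is thus a 1.1-fold higher number from compound 3 to compound 4 (0.04 log units; within the scatter).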

Compound 4, half-maximal inhibitory concentration: 120 nM
Compound 4: middle estimate off by 1.1-fold (0.04 log units), on the low side; low and high end bracket the measured number.
By their numbers in this assay, from the lowest: compounds 1, 3, 2 and 4 (each within the scatter of the next).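

On the saturated chain carbon bound to an amine nitrogen and an aromatic carbon, butyl in place of phenyl gives a 1.2-fold higher number from compound 3 to compound 4 (0.08 log units; within the scatter) in this assay, while butyl in place of hydrogen gives a 1.2-fold higher number from compound 1 to compound 4 (0.08 log units; within the scatter) in the same assay. Until now, with benzyl on the aromatic nitrogen, this carbon had carried only hydrogen or a phenyl ring; compound 4 adds an open chain with no ring, and hydrogen, phenyl and butyl cannot be told apart in these numbers. Nothing available here explains why these three groups read alike.

Still open is whether this carbon would accept a group of a different kind, such as an amine or a carboxylic acid, or a chain longer than butyl, as hydrogen and the two carbon-only groups shown say nothing about those. Among these compounds, also open is whether butyl would read the same with cyclohexyl in place of benzyl on the aromatic nitrogen: the only compound with cyclohexyl there, compound 2, carries phenyl on this carbon.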